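This account rests on a few compounds, and the source may have more. Where it says the series, first, only, none or still open, it means among the compounds named here.

Working notes on the series in an ADME assay on cells (spleen, Mus musculus, strain C57BL/6) for inhibition, read by flow cytometry and propidium iodide staining, with a stated time of 24 h, at 37 degrees C; on this read-out lower numbers stand for an effect already at smaller amounts and higher numbers for an effect only at larger amounts of compound: compound 1 (`O=C(Cn1cc(CO)nn1)NCc1ccccc1`) gives 490 uM, compound 2 (`O=C(O)CCc1cn(CC(=O)NCc2ccccc2)nn1`) gives 1420 uM and compound 3 (`Nc1cccc(-c2cn(CC(=O)NCc3ccccc3)nn2)c1`) gives 800 uM. Compound 3 is not separated from either of the other two. Compound 4 (`Cc1ccccc1-c1cn(CC(=O)NCc2ccccc2)nn1`) has 2-methylphenyl in place of 3-aminophenyl on an aromatic carbon. Two measured steps change the group at this place, a 1.6-fold higher number from compound 1 to compound 3 (0.21 log units; within the scatter) and a 1.8-fold lower number from compound 2 to compound 3 (0.25 log units; within the scatter), and both stay within the scatter. For the measured compounds named here, the only step beyond it, a 2.9-fold higher number from compound 1 to compound 2 (0.46 log units; beyond the scatter), is modest. Going by the values given here, no measured step exchanges one substituted phenyl for another. In this assay the expected result is therefore no change beyond the scatter, an estimated 1.2-fold lower number from compound 3 to compound 4 (0.09 log units; within the scatter). Compound 4 is estimated at 650 uM, with an expected range from 280 uM to 1500 uM.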

Compound 4, concentration for half-maximal effect: 940 uM
Estimate against measurement, compound 4: 1.4-fold (0.16 log units) below; the range from low to high includes it.
By their numbers in this assay, from the lowest: compounds 1, 3, 4 and 2 (each within the scatter of the next, the first and the last beyond it).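

In this assay the exchange of one substituted phenyl for another gives a 1.2-fold higher number from compound 3 to compound 4 (0.07 log units; within the scatter) even though the hydrogen-bond donor and acceptor counted on 3-aminophenyl are gone in 2-methylphenyl. The steps of a 1.5-fold lower number from compound 2 to compound 4 (0.18 log units; within the scatter) and a 1.9-fold higher number from compound 1 to compound 4 (0.28 log units; within the scatter) also stay within the scatter, so 2-methylphenyl is not separated from any of the three earlier groups at this aromatic carbon. Nothing available explains these results.

Open, on these data alone, is whether a phenyl bearing a carboxylic acid, or a longer alkyl chain on this aromatic carbon, would give a step beyond the scatter.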